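The source may report more compounds than this note shows. Statements on the series, on what has been measured and on what is new or still open speak of the compounds shown alone.

Compound 1 `Cc1ccccc1Nc1nc(C)c(C(=O)/C=C/c2ccccc2Cl)s1`: in a functional assay on Bel-7402 cells (Homo sapiens) for cytotoxicity, read by MTT assay (on this read-out lower numbers stand for stronger inhibition and higher numbers for weaker inhibition), compound 1 gives > 25000 nM, which is a limit of the assay and not a number.
Compound 2 `Cc1ccc(Nc2nc(C)c(C(=O)/C=C/c3ccccc3Cl)s2)cc1`: in this assay compound 2 gives > 25000 nM, again a limit and not a number.

Compound 1 therefore stands at the limit only; nothing finer is known of its place. Within the data shown here, the one measured step, with 4-methylphenyl in place of 2-methylphenyl on a nitrogen on an aromatic ring, is a step that the two limits leave unreadable from compound 1 to compound 2, since both ends sit at the limit of > 25000 nM in this assay, at which 2 of the 2 values shown sit.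

Compound 3 `COc1cccc(/C=C/C(=O)c2sc(Nc3ccccc3C)nc2C)c1` differs from compound 1 at the other end of the shared core: 3-methoxyphenyl in place of 2-chlorophenyl on a double-bonded chain carbon bound to a double-bonded chain carbon. Among the measured compounds shown here, no measured step touches that position, so the only guide is that both compounds seen so far sit at the limit of > 25000 nM in this assay, at which 2 of the 2 values shown sit, and a change at a different place gives no reason to expect a reading that leaves that region. The expected step in this assay is therefore none that can be read, and is written as a step that the limit leaves unreadable from compound 1 to compound 3. Compound 3 is accordingly estimated at 30000 nM, with a range from 8000 nM to 100000 nM, and most likely the assay again reports only a limit.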

Compound 3, half-maximal inhibitory concentration: > 25000 nM
Compound 3: no number, only a limit; the forecaster's own chance of this, stated with the estimate: 75%; the middle value is on the limit's open side.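

In this assay compound 3 gives > 25000 nM, which is a limit and not a number. No step can be read between compound 1 and compound 3, because both stop at the same limit: the limit of > 25000 nM in this assay, at which 3 of the 3 values shown sit. The compounds shown leave open how far any of them lies from that limit, and whether any change to the shared core gives a readable value.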